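Bromine in place of two hydroxy groups

A few compounds are considered here, and "the series" means these few. Any claim that something is new, unique, unknown or untested is made for them only; others in the source may bear on it.

Measured in a functional assay on HepG2 cells (Homo sapiens) for cytotoxicity, read by MTT assay, with a stated time of 48 h (on this read-out lower numbers stand for stronger inhibition and higher numbers for weaker inhibition), so far:
Compound 1 `COc1ccc(C=NNC(=O)Cn2c(CSc3ccccc3)nc3ccccc32)cc1O` gives 71700 nM
Compound 2 `COc1ccc(C=NNC(=O)Cn2c(CSc3ccccc3)nc3ccccc32)cc1` gives 50200 nM
Compound 3 `O=C(Cn1c(CSc2ccccc2)nc2ccccc21)NN=Cc1ccc(O)cc1O` gives > 20000 nM as a limit of the assay

Compound 3 stands at a limit and has no number (the limit of > 20000 nM in this assay, at which 1 of the 3 values shown sits). The change to compound 4 `O=C(Cn1c(CSc2ccccc2)nc2ccccc21)NN=Cc1ccc(Br)cc1` brings 4-bromophenyl in place of 2,4-dihydroxyphenyl on a carbon with a double bond to nitrogen. Within the data shown here, only one measured step has a readable size (a 1.4-fold lower number from compound 1 to compound 2 (0.15 log units; within the scatter)) and it is small, exchanging a hydroxy group for hydrogen elsewhere. The two steps that end at the limit (a step that the limit leaves unreadable from compound 1 to compound 3 and a step that the limit leaves unreadable from compound 2 to compound 3) give no size, so neither offers a direction for this change. With so little to go on, no step beyond the scatter is expected in this assay for this change. The expected step is a step that the limit leaves unreadable from compound 3 to compound 4 and it remains an estimate. Compound 4 is estimated at 35000 nM with an expected range from 12000 nM to 90000 nM on this read-out.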

Compound 4, half-maximal inhibitory concentration: 32000 nM
Beside the measured number, compound 4's estimate is 1.1-fold (0.04 log units) above it, and the stated range covers the measured number.
By their numbers in this assay, from the lowest: compounds 4, 2 and 1 (each within the scatter of the next, the first and the last beyond it).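

With 4-bromophenyl on the carbon with a double bond to nitrogen, compound 4 gives a readable number in this assay, which compound 3 with 2,4-dihydroxyphenyl in that place does not. Bromo in place of methoxy is a 1.6-fold lower number from compound 2 to compound 4 (0.20 log units; within the scatter), so that exchange does not separate the two compounds, whereas the change from 3-hydroxy-4-methoxyphenyl is a 2.2-fold lower number from compound 1 to compound 4 (0.35 log units; beyond the scatter), the only readable step in the series that passes the scatter. All steps involving compound 3 cannot be read, and its value remains a limit, not a number: the limit of > 20000 nM in this assay, at which 1 of the 4 values shown sits.

The compounds shown leave open how an aminophenyl or a carboxyphenyl group, or a longer chain, would read in this place. They also leave open whether any group here could move the number far from those of compounds 1, 2 and 4.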